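The source may report more compounds than this note shows. Statements on the series, on what has been measured and on what is new or still open speak of the compounds shown alone.

In a functional assay on MGC-803 cells (Homo sapiens) for cytotoxicity, read by MTT assay, with a stated time of 72 h (a higher number here means a weaker inhibitor, a lower number a stronger inhibitor), compound 3 `O=C(CCl)Nc1ccc(C(=O)/C=C/c2ccc(Cl)cc2)cc1` gives 4960 nM, the lowest of the two numbers in hand. Compound 1 `Cc1cccc(NC(=O)CSC(=S)N[C@H]2CCOC2=O)c1` gives 36600 nM in this assay, a higher number than that of compound 3 and a gap beyond the scatter. Compound 2 `CSC(=S)N[C@H]1CCOC1=O` gives > 128000 nM; that reading is the limit of > 128000 nM in this assay, at which 1 of the 3 values shown sits, a limit rather than a measured number. Compound 4 `Cc1ccc(/C=C/C(=O)c2ccc(NC(=O)CCl)cc2)cc1` has not yet been measured. It differs from compound 3 by methyl in place of chloro on an aromatic carbon. Going by the values given here, no pair of measured compounds shows a change of this kind, so its size cannot be read from the data in hand. The step expected here is a 1.2-fold higher number from compound 3 to compound 4 (0.08 log units; within the scatter), nothing beyond the scatter. Compound 4 is therefore expected to give about 6000 nM, between 2500 nM and 15000 nM.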

Compound 4, half-maximal inhibitory concentration: 3600 nM
Estimate against measurement, compound 4: 1.7-fold (0.22 log units) above; measured number inside the range.
By their numbers in this assay, from the lowest: compounds 4 and 3 (each within the scatter of the next); then compound 1. At a limit, above all of these: compound 2.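

In this assay, going by these compounds alone, the change from 4-chlorophenyl to 4-methylphenyl gives a 1.4-fold lower number from compound 3 to compound 4 (0.14 log units; within the scatter) as the first measured step of this kind. At this position on the shared core, then, methyl and chloro cannot be told apart in this assay. No measurement in hand bears on why the two groups read alike.

From the compounds shown here alone, whether an amine, a methoxy group or a carboxylic acid at this position would also read alike remains open. This single pair also says nothing about changes elsewhere on the core.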